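The source may hold more compounds than are shown below. What is called first, only, known or untested is meant among the compounds shown, and "the series" means these compounds.

In a functional assay on KYSE-410 cells (Homo sapiens) for antiproliferative activity, read by MTT assay, with a stated time of 72 h (on this read-out higher numbers stand for weaker inhibition and lower numbers for stronger inhibition), two compounds sharing one core have been tested so far. Compound 1 `CC(C)(C)c1ccc(-c2ccc3c(C(=O)Nc4cccc(F)c4)cc(=O)[nH]c3c2)cc1` gives > 20000 nM, which is a limit of the assay and not a number. Compound 2 `O=C(Nc1cccc(F)c1)c1cc(=O)[nH]c2cc(-c3ccc(F)nc3)ccc12` gives > 20000 nM, which is also a limit. Compound 2 therefore has no exact place on the scale: it sits with compound 1 at the limit of > 20000 nM in this assay, at which 2 of the 2 values shown sit. Within the data shown here, the only measured comparison is a step that the two limits leave unreadable from compound 1 to compound 2, so it offers no size of step to carry forward, though neither of the two groups tried at this position gave a readable value.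

Compound 3 `C#Cc1ccc2c(C(=O)Nc3cccc(F)c3)cc(=O)[nH]c2c1` differs from compound 2 by one change, ethynyl in place of 6-fluoropyridin-3-yl on an aromatic carbon. No measured step involves ethynyl, so the data give no reason to expect a gain or a loss in this assay, and no step beyond the usual scatter is predicted. The expected change is a number no higher from compound 2 to compound 3 (the limit leaves the size open), and this remains an estimate resting on very little. A report of only a limit again seems the likeliest outcome. For compound 3 the estimated value is 20000 nM, with an expected range from 7000 nM to 50000 nM.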

Compound 3, half-maximal inhibitory concentration: 9700 nM
Compound 3: middle estimate off by 2.1-fold (0.31 log units), on the high side, within the range that was stated.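

Among these compounds, on this aromatic carbon, ethynyl is the only group among the three that gives an exact value in this assay, which shows that the position can carry measurable activity on the shared core. Ethynyl in place of 6-fluoropyridin-3-yl gives an at least 2.0-fold lower number from compound 2 to compound 3 (0.31 log units; beyond the scatter), and ethynyl in place of 4-(tert-butyl)phenyl gives an at least 2.0-fold lower number from compound 1 to compound 3 (0.31 log units; beyond the scatter). Ethynyl has no ring, whereas both groups it replaces do, and both of those compounds remain at a limit of the assay and not a number, so each step gives only a minimum size, and the full size stays unknown: the limit of > 20000 nM in this assay, at which 2 of the 3 values shown sit.

The three compounds cannot separate the effect of removing the ring from that of adding the triple bond, and a nitrile, a methyl group or a cyclopropyl group on the same carbon would help to tell these apart. Going by these compounds, it also remains open whether a longer chain ending in a triple bond, or an amine at this position, would lower the number further, and whether the gain would hold with a different group on the amide.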